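Hydroxy to chloro on the pendant phenyl

This account rests on a few compounds, and the source may have more. Where it says the series, first, only, none or still open, it means among the compounds named here.

Compound 1 `Clc1ccc(-c2nc(N3CCCCC3)c3nc[nH]c3n2)cc1Cl` and compound 2 `Oc1cccc(-c2nc(N3CCCCC3)c3nc[nH]c3n2)c1` share one core. In an assay on cells for displacement of a labelled ligand from adenosine receptor A3 (Homo sapiens), read by scintillation counting and radioligand binding, with a stated time of 180 min, tested at 10 uM (a lower number here means less inhibition, a higher number more inhibition at the concentration tested (going by the name of the read-out)), compound 1 gives > 80%, which is a limit of the assay and not a number. In this assay compound 2 likewise gives > 80%, again a limit. Among the measured compounds shown here, both values sit at the limit of > 80% in this assay, at which 2 of the 2 values shown sit, so no measured step within or beyond the scatter can be read from them. Compound 3 `Clc1cccc(-c2nc(N3CCCCC3)c3nc[nH]c3n2)c1` is not yet measured; it differs from compound 2 by chloro in place of hydroxy on an aromatic carbon. No change beyond the scatter is expected, so the step from compound 2 to compound 3 is estimated at a step that the limit leaves unreadable from compound 2 to compound 3. Compound 3 is expected to give 85% in this assay, within 65% to 97%.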

Compound 3, a percentage reported as inhibition, at one concentration (the size of the read-out at that concentration, not a potency): > 80%
Compound 3 gave a limit, no number; the forecaster's own chance of this, stated with the estimate: 65%; the middle value does not contradict the limit.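

Compound 1, compound 2 and compound 3 all give limits of the assay, not numbers, so no step among them can be read in this assay: the limit of > 80% in this assay, at which 3 of the 3 values shown sit.

The compounds shown leave open whether 3-hydroxyphenyl and 3-chlorophenyl differ at all in this assay.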